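A few compounds are considered here, and "the series" means these few. Any claim that something is new, unique, unknown or untested is made for them only; others in the source may bear on it.

In a functional assay on MGC-803 cells (Homo sapiens) for inhibition, read by MTT assay, with a stated time of 72 h (a higher number here means a weaker inhibitor, a lower number a stronger inhibitor), the measured compounds give these values

- Compound 1 `O=C(Nc1ccccc1)C1CCN(C/C=C/c2ccccc2)CC1` gives 57900 nM
- Compound 2 `Cc1ccc(NC(=O)C2CCN(C/C=C/c3ccccc3)CC2)cc1` gives 24100 nM
- Compound 3 `CCCc1ccc(NC(=O)C2CCN(C/C=C/c3ccccc3)CC2)cc1` gives 5210 nM

Compound 1 has the highest number of the three, so it is the weakest inhibitor among them. Compound 4 `CCCCc1ccc(NC(=O)C2CCN(C/C=C/c3ccccc3)CC2)cc1` has butyl in place of hydrogen on an aromatic carbon and is otherwise the same. Among the measured compounds shown here, three measured steps bear on this change. Methyl gave a 2.4-fold lower number from compound 1 to compound 2 (0.38 log units; beyond the scatter) and propyl gave an 11-fold lower number from compound 1 to compound 3 (1.05 log units; beyond the scatter) while going from methyl to propyl gave a 4.6-fold lower number from compound 2 to compound 3 (0.67 log units; beyond the scatter) so longer chains have so far lowered the number. Butyl is longer still, so a large step to a lower number is expected in this assay although three compounds cannot show whether the trend continues. The expected step is a 17-fold lower number from compound 1 to compound 4 (1.22 log units; beyond the scatter) in this estimate. The estimated value for compound 4 is 3500 nM with an expected range from 1500 nM to 8000 nM as its limits.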

Compound 4, half-maximal inhibitory concentration: 2570 nM
Beside the measured number, compound 4's estimate is 1.4-fold (0.13 log units) above it, and the stated range covers the measured number.
By their numbers in this assay, from the lowest: compound 4; then compound 3; then compound 2; then compound 1.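

Butyl carries the trend further in this assay with a 23-fold lower number from compound 1 to compound 4 (1.35 log units; beyond the scatter) as the largest step yet from the compound with hydrogen at this place, so all four compounds now fall in order of chain length and none goes against it. The single carbon added to propyl still counts with a 2.0-fold lower number from compound 3 to compound 4 (0.31 log units; beyond the scatter) and the wider jump from methyl gives a 9.4-fold lower number from compound 2 to compound 4 (0.97 log units; beyond the scatter) so the fall does not stop at propyl. Nothing measured here says why the number falls as the chain grows.

From the compounds shown here alone, whether a longer chain such as pentyl or hexyl would lower the number further remains open. So does whether a branched chain, an ether or an amine at this place would behave like butyl.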